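Acetyl on the amine of compound 2

The source may hold more compounds than are shown below. What is called first, only, known or untested is meant among the compounds shown, and "the series" means these compounds.

Measured so far:
- compound 1 `Cn1ncc([N+](=O)[O-])c1C(=O)Nc1nc(-c2ccc(Cl)c(Cl)c2)cs1`: < 1000 nM (a limit)
- compound 2 `NC1=NN(c2ccc(Cl)c(Cl)c2)CC1`: 69000 nM (a number)

Within the data shown here, in a physicochemical assay for solubility, measured as kinetic solubility, with a stated time of 1 h, at pH 7.4 (on this read-out higher numbers stand for higher solubility and lower numbers for lower solubility), compound 2 gives the only actual number at 69000 nM and has no numeric neighbour to be ranked against. Compound 1 reports only the limit < 1000 nM and no number. Compound 3 `CC(=O)NC1=NN(c2ccc(Cl)c(Cl)c2)CC1` has acetyl in place of hydrogen on an amine nitrogen and is not yet measured. Among the measured compounds shown here, no measured step bears on this change, so a fall beyond the scatter in this assay is only a loose expectation. The expected 4.6-fold lower number from compound 2 to compound 3 (0.66 log units; beyond the scatter) is downward. Compound 3 is estimated at 15000 nM ( range 3000 nM to 60000 nM).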

Compound 3, solubility: 31000 nM
Compound 3: middle estimate off by 2.1-fold (0.32 log units), on the low side; low and high end bracket the measured number.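

In this assay, among these compounds, the amine nitrogen takes acetyl in place of hydrogen with a 2.2-fold lower number from compound 2 to compound 3 (0.35 log units; beyond the scatter) as the first measured step. With acetyl on this nitrogen compound 3 still reads 31000 nM and not a limit of the assay. Among the compounds shown here, no earlier pair of compounds bore on this position or on the change from amino to acetamido.

On these data alone, whether methyl, a longer acyl chain such as propionyl, or a carboxylic acid on this nitrogen would shift the number in the same direction stays open. Nothing shown gives a cause for this step.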